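Swapping 3-(trifluoromethyl)phenyl for hydrogen on compound 1

The source may hold more compounds than are shown below. What is called first, only, known or untested is meant among the compounds shown, and "the series" means these compounds.

Measured so far in an ADME assay on L6 cells (Rattus norvegicus) for cytotoxicity, read by microscopy and resazurin assay, with a stated time of 72 h (a lower number here means that less compound is needed, a higher number that more compound is needed for the effect), for the two compounds:
Compound 1 `Cc1cc(/C=C2\S/C(=N\c3ccccc3)N(C3CCCCC3)C2=O)c(C)n1-c1cccc(C(F)(F)F)c1` gives > 170000 nM as a limit
Compound 2 `O=C1/C(=C/c2ccn(Cc3ccccc3)c2)S/C(=N\c2ccccc2)N1C1CCCCC1` gives > 200000 nM as a limit

Compound 1 has no exact number on this scale, only its limit of > 170000 nM in this assay as its reading. Compound 2 is in the same situation, so the two compounds cannot be put in order.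

Compound 3 `Cc1cc(/C=C2\S/C(=N\c3ccccc3)N(C3CCCCC3)C2=O)c(C)[nH]1` keeps the core of compound 1 but has hydrogen in place of 3-(trifluoromethyl)phenyl on an aromatic nitrogen of a five-membered aromatic ring with 1 nitrogen. Going by the values given here, no measured step shows what such a swap does, so the expectation is loose. Neither measured compound gave a number, which points to a small shift at most, perhaps toward a lower number and perhaps none beyond the scatter. Another limit reading is quite possible. The expected change is an at least 1.4-fold lower number from compound 1 to compound 3 (0.15 log units; that floor lies within the scatter) as a rough estimate. Compound 3 is estimated at 120000 nM in this assay with an expected range from 40000 nM to 250000 nM for the measurement.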

Compound 3, half-maximal effective concentration: 23000 nM
The estimate for compound 3 lay 5.2-fold (0.72 log units) above the measured number; measured number below the stated range.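

Going by these compounds alone, compound 3 is the first compound here to give an exact number in this assay, where it reads 23000 nM. Hydrogen in place of 3-(trifluoromethyl)phenyl on the aromatic nitrogen gives an at least 7.3-fold lower number from compound 1 to compound 3 (0.86 log units; beyond the scatter), so the group on this nitrogen clearly affects how much compound is needed for the effect on these cells, a change the two limit readings alone could not reveal. The true size of the step remains unknown and the printed figure is only its floor, because compound 1 has a limit and not an exact number: the limit of > 170000 nM in this assay, at which 1 of the 3 values shown sits.

Within the data shown here, only two groups can be compared on this nitrogen, hydrogen and 3-(trifluoromethyl)phenyl, so it remains open whether the hydrogen itself matters or whether the large aromatic group is simply what raises the number. A methyl group, a longer chain or a chain ending in an amine at the same place could show whether the reading rises gradually with the size of the group or depends on something else.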